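The source may hold more compounds than are shown below. What is called first, only, known or untested is meant among the compounds shown, and "the series" means these compounds.

Measured in a functional assay on SW480 cells (Homo sapiens) for antiproliferative activity, read by MTT assay, with a stated time of 48 h; a higher number here means a weaker inhibitor, a lower number a stronger inhibitor:
- compound 1 `CC(CCO)n1cnc2c(Cl)nc(F)nc21`: 16800 nM
- compound 2 `CCCC(CCO)n1cnc2c(Cl)nc(F)nc21`: 17200 nM
- compound 3 `CCCC(CCO)n1cnc2c(Cl)ncnc21`: > 50000 nM

For compound 3 this value is a limit of the assay, not a number. Level with compound 1 within the scatter, compound 2 gives 17200 nM. Compound 4 `CCCCCCCCC(CCO)n1cnc2c(Cl)nc(F)nc21` changes compound 2 at one place: pentyl in place of hydrogen on a saturated chain carbon, four bonds along the chain from an aromatic nitrogen. The closest guide is a chain change, a 1.0-fold higher number from compound 1 to compound 2 (0.01 log units; within the scatter). The other step, an at least 2.9-fold higher number from compound 2 to compound 3 (0.46 log units; beyond the scatter), concerns the fluoro, not the chain, so it bears little on this change. No step beyond the scatter is therefore expected, though this addition is larger and the uncertainty is wide. The estimate is a 1.3-fold lower number from compound 2 to compound 4 (0.12 log units; within the scatter). For compound 4 the expected value is 13000 nM, with an estimated range of 4500 nM to 36000 nM.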

Compound 4, half-maximal inhibitory concentration: 15000 nM
Compound 4: the middle estimate sits 1.2-fold (0.06 log units) below what was measured; the range from low to high includes it.
By their numbers in this assay, from the lowest: compounds 4, 1 and 2 (each within the scatter of the next). At a limit, above all of these: compound 3.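

In this assay, adding pentyl gives a 1.1-fold lower number from compound 2 to compound 4 (0.06 log units; within the scatter), and adding heptyl gives a 1.1-fold lower number from compound 1 to compound 4 (0.05 log units; within the scatter). This chain carbon therefore accepts a much longer chain than the ethyl of the earlier step without a change beyond the scatter. These comparisons rest on numbers, not on the assay limit reached by compound 3 alone: the limit of > 50000 nM in this assay, at which 1 of the 4 values shown sits.

Still open, going by these compounds, is whether a chain ending in an amine or a carboxylic acid would move the number at this position. Also open, on these data alone, is whether hydrogen in place of fluoro would matter as much in compound 4.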